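The compounds below may be only part of what the source reports. "The series", "measured", "known", "first", "only" and "open" are said of these compounds alone.

In a toxicity assay on MT4 cells (Homo sapiens) for cytotoxicity, read by MTT assay (a lower number here means that less compound is tolerated, a higher number that more compound is tolerated), compound 1 `Cc1cc(-c2ccc(C#N)c(C#N)c2)ccc1Oc1cc(N)nc(Nc2ccc(C#N)cc2)n1` gives 76700 nM and compound 2 `Cc1cc(-c2ccccc2F)cc(C)c1Oc1cc(N)nc(Nc2ccc(C#N)cc2)n1` gives 29300 nM while compound 3 `Cc1cc(-c2ccccc2)ccc1Oc1cc(N)nc(Nc2ccc(C#N)cc2)n1` gives 20000 nM as the number to start from. Compound 3 shares the low end of the three numbers with compound 2, the two lying within the scatter of each other. Compound 4 `Cc1cc(-c2ccccc2F)ccc1Oc1cc(N)nc(Nc2ccc(C#N)cc2)n1` differs from compound 3 by one change, fluoro in place of hydrogen on an aromatic carbon so that phenyl becomes 2-fluorophenyl. For the measured compounds named here, the one measured step at this group is a 3.8-fold lower number from compound 1 to compound 3 (0.58 log units; beyond the scatter) for phenyl in place of 3,4-dicyanophenyl, a larger change than a single fluoro. Compound 2 also holds a 2-fluorophenyl group, though it differs elsewhere too, and its 29300 nM stays within the scatter of compound 3. No step beyond the scatter is therefore expected in this assay and the estimated step is a 1.2-fold higher number from compound 3 to compound 4 (0.06 log units; within the scatter) in size. Compound 4 is estimated at 23000 nM with 11000 nM to 50000 nM as its expected range.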

Compound 4, half-maximal cytotoxic concentration: 29500 nM
Estimate against measurement, compound 4: 1.3-fold (0.11 log units) below, within the range that was stated.
By their numbers in this assay, from the lowest: compounds 3, 2 and 4 (each within the scatter of the next); then compound 1.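

In this assay fluoro in place of hydrogen on the phenyl group (a 1.5-fold higher number from compound 3 to compound 4 (0.17 log units; within the scatter)) stays within the scatter, so this aromatic carbon takes fluoro without a readable shift. Hydrogen in place of methyl (a 1.0-fold higher number from compound 2 to compound 4 (0.00 log units; within the scatter)) also stays within the scatter, whereas 2-fluorophenyl in place of 3,4-dicyanophenyl (a 2.6-fold lower number from compound 1 to compound 4 (0.41 log units; beyond the scatter)) lies beyond it, as the step to plain phenyl did. No measurement shown here offers an explanation for these numbers. On these data alone, whether an amine or a carboxylic acid at this aromatic carbon would shift the number stays open.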